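The source may report more compounds than this note shows. Statements on the series, on what has been measured and on what is new or still open speak of the compounds shown alone.

Measured in an ADME assay on THP-1 cells (Homo sapiens) for cytotoxicity, read by flow cytometry and propidium iodide staining, with a stated time of 72 h; on this read-out lower numbers stand for stronger inhibition and higher numbers for weaker inhibition:

Compound 1, `CC(=O)Nc1ccc2oc(-c3ccccc3F)c(O)c(=O)c2c1`: 47000 nM
Compound 2, `CC(=O)Nc1ccc2oc(-c3cccc(F)c3)c(O)c(=O)c2c1`: 36000 nM
Compound 3, `COc1c(-c2ccccc2F)oc2ccc(NC(C)=O)cc2c1=O`: a limit of the assay, > 125000 nM

Compounds 1 and 2 share one core and differ by 3-fluorophenyl in place of 2-fluorophenyl on an aromatic carbon. In this assay this gives a 1.3-fold lower number from compound 1 to compound 2 (0.12 log units; within the scatter). Compound 3 differs from compound 1 in its core by methyl in place of hydrogen on an oxygen on an aromatic ring, and in this assay that step reads an at least 2.6-fold higher number from compound 1 to compound 3 (0.42 log units; beyond the scatter). For compound 3 only a limit is known, namely (the limit of > 125000 nM in this assay, at which 1 of the 3 values shown sits).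

Compound 4, `COc1c(-c2cccc(F)c2)oc2ccc(NC(C)=O)cc2c1=O`, has not yet been measured in this assay. It differs from compound 3 by 3-fluorophenyl in place of 2-fluorophenyl on an aromatic carbon. Around the place, compound 3 carries the group ortho to a methoxy group (2 heavy atoms), whereas compound 1 carries it ortho to a hydroxy group (1 heavy atom), so this is the same kind of change as that from compound 1 to compound 2, not the same change. Because the earlier step of a 1.3-fold lower number from compound 1 to compound 2 (0.12 log units; within the scatter) stayed within the scatter, compound 4 is expected to sit near compound 3, giving an estimated step that the limit leaves unreadable from compound 3 to compound 4. Compound 4 is therefore estimated at 150000 nM in this assay, between 60000 nM and 400000 nM, most likely reported as a limit again.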

Compound 4, half-maximal inhibitory concentration: > 125000 nM
Compound 4: only a limit was reported; the forecaster's own chance of this, stated with the estimate: 70%; the middle value lies beyond the limit too.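

Moving from the hydroxy compound to its methoxy partner with the 3-fluorophenyl group gives an at least 3.4-fold higher number from compound 2 to compound 4 (0.54 log units; beyond the scatter). Set beside the same change with the 2-fluorophenyl group, the step runs the same way in both pairs in this assay: the same change on two cores in this assay, an at least 2.6-fold higher number (0.42 log units; beyond the scatter) from compound 1 to compound 3 and an at least 3.4-fold higher number (0.54 log units; beyond the scatter) from compound 2 to compound 4; the limit leaves it open whether they differ
This shows that, in these two pairs, the direction of the change carries from one core to the other, but it does not show how large either step really is or whether the two sizes match, and the step between the two methoxy compounds cannot be read, since compound 3 and compound 4 both stand only as limits of the assay: the limit of > 125000 nM in this assay, at which 2 of the 4 values shown sit.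

The compounds shown leave open whether an ethyl group or a longer chain on that oxygen would raise the number in the same way as methyl. They also leave open whether the same change would carry to a core bearing 4-fluorophenyl, or one with an amine or a carboxylic acid on the phenyl ring.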